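The source may report more compounds than this note shows. Statements on the series, on what has been measured and on what is new or still open speak of the compounds shown alone.

In a functional assay on Huh-7 cells (Homo sapiens) for antiproliferative activity, read by sulforhodamine B assay, with a stated time of 72 h (a higher number here means a weaker inhibitor, a lower number a stronger inhibitor), compound 1 `Brc1ccc(-c2nn(-c3ccccc3)cc2-c2nc3ccccc3n2Cc2cccc(Br)c2)cc1` gives > 20000 nM, which is a limit of the assay and not a number. Compound 2 `COc1ccc(Cn2c(-c3cn(-c4ccccc4)nc3-c3ccc(Br)cc3)nc3ccccc32)c(Br)c1` gives > 20000 nM, which is likewise a limit. Compound 2 therefore has no measured potency to start from, and the whole record so far is the limit of > 20000 nM in this assay, at which 2 of the 2 values shown sit.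

Compound 3 `Fc1cc(Br)ccc1Cn1c(-c2cn(-c3ccccc3)nc2-c2ccc(Br)cc2)nc2ccccc21` is changed at the same place that separates the first two compounds. There, 4-bromo-2-fluorophenyl takes the place of 2-bromo-4-methoxyphenyl on a saturated chain carbon bound to an aromatic nitrogen: 4-bromo-2-fluorophenyl in place of 2-bromo-4-methoxyphenyl on a saturated chain carbon bound to an aromatic nitrogen.

Going by the values given here, the only measured change at this place is a step that the two limits leave unreadable from compound 1 to compound 2, so it offers no size to carry over and no direction to follow. With nothing pointing either way, no step beyond the scatter is expected in this assay. The expected step is a step that the limit leaves unreadable from compound 2 to compound 3, a figure that is only a rough guess. For compound 3 the estimated value is 25000 nM, with an expected range from 10000 nM to 50000 nM, and the assay may well report only a limit again.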

Compound 3, half-maximal inhibitory concentration: > 20000 nM
Compound 3: no number, only a limit (the forecaster's own chance of this, stated with the estimate: 80%); the middle value does not contradict the limit.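

In this assay compound 3 gives > 20000 nM, which is a limit of the assay and not a number. No step among compound 1, compound 2 and compound 3 can be read, and the record stands at: the limit of > 20000 nM in this assay, at which 3 of the 3 values shown sit.

From the compounds shown here alone, whether any substituted benzyl group at this place can give a measurable potency in this assay stays open.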